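The source may report more compounds than this note shows. Statements on the series, on what has been measured and on what is new or still open speak of the compounds shown alone.

Measured in a functional assay (aorta) with Rattus norvegicus as the target, in the presence of a further agent that is not named here; a lower number here means that less compound is needed, a higher number that more compound is needed for the effect:

- Compound 1 `COC(=O)C1=C(C)N=C(C)/C(=C(/O)OC)C1c1ccccc1OCCO[N+](=O)[O-]`: 56 nM
- Compound 2 `COC(=O)C1=C(C)N=C(C)/C(=C(/O)OC)C1c1cccc(OCc2no[n+]([O-])c2C)c1`: 500 nM

Compound 2 holds the higher of these two numbers, so more of it is needed for the effect than of compound 1, and the gap lies beyond the usual scatter. Compound 3 `COC(=O)C1=C(C)N=C(C)/C(=C(/O)OC)C1c1cccc(OCc2nonc2C#N)c1` keeps the rest of compound 2 and exchanges one group: a group of 7 heavy atoms (3 carbon, 3 nitrogen, 1 oxygen; one five-membered aromatic ring with 3 hetero atoms) in place of a group of 7 heavy atoms (3 carbon, 2 nitrogen, 2 oxygen; one five-membered aromatic ring with 3 hetero atoms), on a saturated chain carbon bound to an oxygen on an aromatic ring. The group that enters is 4-cyano-1,2,5-oxadiazol-3-yl, on a saturated chain carbon bound to an oxygen on an aromatic ring. Going by the values given here, no two measured compounds differ in one place only, so nothing here shows what such an exchange does. The expectation is therefore a cautious one: no step beyond the scatter in this assay, in either direction. The expected change is a 1.3-fold lower number from compound 2 to compound 3 (0.10 log units; within the scatter). For compound 3 the estimated value is 400 nM, with an expected range from 80 nM to 2000 nM.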

Compound 3, half-maximal effective concentration: 310 nM
Estimate against measurement, compound 3: 1.3-fold (0.11 log units) above; the range from low to high includes it.
By their numbers in this assay, from the lowest: compound 1; then compounds 3 and 2 (each within the scatter of the next).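

In this assay putting 4-cyano-1,2,5-oxadiazol-3-yl in place of the earlier group, on a saturated chain carbon bound to an oxygen on an aromatic ring, gives a 1.6-fold lower number from compound 2 to compound 3 (0.21 log units; within the scatter) and so no real change. This is the first pair shown that differs in one place only, and it shows that these two groups, each with one five-membered aromatic ring and the same count of heavy atoms, cannot be told apart here. No measurement shown speaks to why they behave alike.

Compound 1 differs from both in more than one place, so its number cannot be tied to any single change. On these data alone, it remains open whether a different group at this place, such as an amine, a carboxylic acid or a longer chain, would move the number beyond the scatter.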